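The compounds below may be only part of what the source reports. "The series", "measured", "known", "first", "only" and "open" are said of these compounds alone.

Values from a functional assay on HOP-62 cells (Homo sapiens) for inhibition, read by sulforhodamine B assay (on this read-out higher numbers stand for weaker inhibition of growth and lower numbers for stronger inhibition of growth), so far:

- compound 1 `c1ccc(-c2ccc(-c3ccc(-c4nc5ccccc5[nH]4)cc3)cc2)cc1` gives 100000 nM
- compound 2 `Fc1ccc(-c2ccc(-c3ccc(-c4nc5ccccc5[nH]4)cc3)cc2)cc1` gives 39300 nM
- compound 3 `FC(F)(F)Oc1ccc(-c2ccc(-c3ccc(-c4nc5ccccc5[nH]4)cc3)cc2)cc1` gives 100000 nM

On this assay compound 3 stands level with compound 1 at the top of the three numbers, and only compound 2 sits lower. The next compound to be tested is compound 4 `Oc1ccc(-c2ccc(-c3ccc(-c4nc5ccccc5[nH]4)cc3)cc2)cc1`. It differs from compound 3 by hydrogen in place of trifluoromethyl on an oxygen on an aromatic ring with hydrogen in place of trifluoromethyl on an oxygen on an aromatic ring, so trifluoromethoxy becomes hydroxy.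

Going by the values given here, no measured compound carries a hydroxy group, so the evidence is indirect. The nearest guides are three single-group changes on the shared core. Adding trifluoromethoxy gave no change at the digits printed from compound 1 to compound 3 (within the scatter) and adding fluoro gave a 2.5-fold lower number from compound 1 to compound 2 (0.41 log units; beyond the scatter). Replacing fluoro with trifluoromethoxy gave a 2.5-fold higher number from compound 2 to compound 3 (0.41 log units; beyond the scatter). None of these steps is more than modest, so a modest step is the most that these data support. Since compound 3 already shares the highest number, any change is more likely to be downward, although no change beyond the scatter remains quite possible.

The estimate means a 2.5-fold lower number from compound 3 to compound 4 (0.40 log units; beyond the scatter) as the expected step. For compound 4 the expected value is 40000 nM with an estimated range from 12000 nM to 100000 nM on this read-out.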

Compound 4, concentration for 50% growth inhibition: 47200 nM
The estimate for compound 4 lay 1.2-fold (0.07 log units) below the measured number, and the stated range covers the measured number.
By their numbers in this assay, from the lowest: compounds 2 and 4 (each within the scatter of the next); then compounds 1 and 3 (each within the scatter of the next).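

In this assay, replacing the trifluoromethyl on the oxygen with hydrogen gives a 2.1-fold lower number from compound 3 to compound 4 (0.33 log units; beyond the scatter), so what sits on that oxygen matters, and the oxygen alone does not set the number. Hydroxy in place of hydrogen gives a 2.1-fold lower number from compound 1 to compound 4 (0.33 log units; beyond the scatter), which makes hydroxy the second group after fluoro to move the number below that of the unsubstituted core, while trifluoromethoxy left it unchanged at the digits printed. Hydroxy in place of fluoro gives a 1.2-fold higher number from compound 2 to compound 4 (0.08 log units; within the scatter), so this read-out does not separate these two groups, and no measurement available here explains the differences among the groups at this position.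

Still open, as far as these compounds go, is how a methoxy group would read, since its methyl on the oxygen would fall between the hydrogen and the trifluoromethyl compared here. An amine or a carboxylic acid at the same place could also show whether any group brings the number well below the modest steps seen so far, or whether these compounds stay in this range.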